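The source may report more compounds than this note shows. Statements on the series, on what has been measured and on what is new or still open speak of the compounds shown alone.

Of the compounds shown here, three have been read so far in a physicochemical assay for solubility, read by HPLC, measured as thermodynamic solubility, with a stated time of 4 h, at pH 6.8; on this read-out lower numbers stand for lower solubility and higher numbers for higher solubility. Compound 1 (`Cc1ccc(Oc2ccc3nc(COc4cccc(C(=O)O)c4)n(C)c3n2)cc1F`) gives 5.2 ug/mL, and compound 2 (`Cc1ccc(Oc2cc3c(cn2)nc(COc2cccc(C(=O)O)c2)n3C)cc1`) gives 360 ug/mL. Compound 3 (`Cn1c(COc2cccc(C(=O)O)c2)nc2ccc(Oc3cc(Cl)ccn3)cc21`) gives 11 ug/mL, which makes it the second highest of the three. Compound 1 lies only just beyond the scatter below it, while compound 2 lies far above it. No two of these compounds differ in a single place, so the data hold no direct measure of what one change does.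

Compound 4 (`Cn1c(COc2cccc(C(=O)O)c2)nc2ccc(Oc3ncccc3F)cc21`) has not yet been measured in this assay. It departs from compound 3 in one place, with 3-fluoropyridin-2-yl in place of 4-chloropyridin-2-yl on an oxygen on an aromatic ring. Since nothing measured isolates this swap, the expectation stays anchored on compound 3 at 11 ug/mL. The range is kept wide, as compound 2 at 360 ug/mL shows how far values can spread among these structures. A small rise that does not clearly pass the scatter is expected, and the estimated step is a 1.6-fold higher number from compound 3 to compound 4 (0.21 log units; within the scatter). The expected value for compound 4 is 18 ug/mL, with an estimated range from 6 ug/mL to 60 ug/mL.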

Compound 4, solubility: 7.1 ug/mL
The estimate for compound 4 lay 2.5-fold (0.40 log units) above the measured number; measured number inside the range.
By their numbers in this assay, from the lowest: compounds 1, 4 and 3 (each within the scatter of the next, the first and the last beyond it); then compound 2.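

Within the data shown here, the first single-place comparison in this set comes from this assay, where replacing 4-chloropyridin-2-yl with 3-fluoropyridin-2-yl on an oxygen on an aromatic ring gives a 1.5-fold lower number from compound 3 to compound 4 (0.19 log units; within the scatter). Compound 3 and compound 4 therefore cannot be told apart on this read-out, so this exchange, which alters both the halogen and its ring position while keeping the heavy-atom count, leaves no measurable mark at this position. No independent measurement bears on why the two numbers stay so close.

Because the halogen and its ring position change together in this one step, the compounds shown cannot separate the contribution of each, and they do not reveal whether either halogen matters at all when compared with a plain pyridin-2-yl. As far as these compounds go, it also remains open whether a group of a different kind at this place, such as an amine or a methoxy group in place of the halogen, would produce a step beyond the scatter in this assay.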